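The source may hold more compounds than are shown below. What is called first, only, known or untested is meant among the compounds shown, and "the series" means these compounds.

Four amides built on a chain carrying two sulfur atoms are compared in a functional assay on KB cells (Homo sapiens) for inhibition, read by MTT assay, with a stated time of 24 h, tested at 100 ug/mL; on this read-out lower numbers stand for less inhibition of growth and higher numbers for more inhibition of growth at the one concentration tested. Compound 1 `O=C(CCCCC1CCSS1)Nc1cccc(C(F)(F)F)c1` gives 80% in this assay. Compound 3 `O=C(CCCCC(S)CCS)Nc1cccc(C(F)(F)F)c1` carries a group of 5 heavy atoms (3 carbon, 2 sulfur; no ring) in place of a group of 5 heavy atoms (3 carbon, 2 sulfur; one five-membered non-aromatic ring with 2 hetero atoms), on a saturated chain carbon, four bonds along the chain from a carbonyl carbon and gives 30.5% in this assay; the step is a number 49.5 percentage points lower from compound 1 to compound 3 (beyond the scatter). Compound 2 `O=C(CCCCC1CCSS1)Nc1cccc2ccccc12` has a different core, and the difference between the two cores is not broken down here; in this assay compound 2 is reported as "not active" (no number reported), so no number stands for it. Compound 4 `O=C(CCCCC(S)CCS)Nc1cccc2ccccc12` is not yet measured; it relates to compound 2 through (a group of 5 heavy atoms (3 carbon, 2 sulfur; no ring) in place of a group of 5 heavy atoms (3 carbon, 2 sulfur; one five-membered non-aromatic ring with 2 hetero atoms), on a saturated chain carbon, four bonds along the chain from a carbonyl carbon), the same change that turns compound 1 into compound 3. Because the change lowered growth inhibition in the step of a number 49.5 percentage points lower from compound 1 to compound 3 (beyond the scatter), and because compound 2 already shows "not active" (no number reported), compound 4 is expected to show little inhibition in this assay. The expected value for compound 4 in this assay is 12%, estimated to lie between 0% and 35%. Within the data shown here, only one measured pair carries this change, so the expectation rests on a single step and on an inactive starting point.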

Compound 4, percent growth inhibition at one concentration: "not active" (no number reported)
No number was reported for compound 4; no gap can be computed for the estimate.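

In this assay compound 2 gives "not active" (no number reported) and compound 4 gives "not active" (no number reported), so no step can be read between these two compounds. The compounds shown leave open whether the 1,3-disulfanylpropyl group in place of the ring changes growth inhibition at all on the core of compound 2. No supporting evidence bears on this result.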